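The source may report more compounds than this note shows. Statements on the series, on what has been measured and on what is new or still open speak of the compounds shown alone.

In a functional assay on HCT-116 cells (Homo sapiens) for antiproliferative activity, with a stated time of 72 h (a higher number here means a weaker inhibitor, a lower number a stronger inhibitor), compound 1 (`CC(=O)Oc1ccccc1/C=C/c1nc(Nc2ccccc2I)c2ccccc2n1`) gives > 25000 nM as a limit and not a number. Compound 2 (`COc1ccccc1/C=C/c1nc(Nc2cccc(O)c2)c2ccccc2n1`) reads 21700 nM and compound 3 (`O=[N+]([O-])c1cccc(/C=C/c2nc(Nc3cccc(O)c3)c3ccccc3n2)c1`) reads 10900 nM with the two values within the scatter of each other, so compound 3 cannot be separated from compound 2 on these numbers. Compound 4 (`Oc1cccc(Nc2nc(/C=C/c3cccc(Cl)c3)nc3ccccc23)c1`) differs from compound 3 by chloro in place of nitro on an aromatic carbon. Among the compounds with values here, the one measured step bearing on this change is a 2.0-fold lower number from compound 2 to compound 3 (0.30 log units; within the scatter) and it stays within the scatter, while no measured step exchanges nitro directly. The expected size of a 1.0-fold higher number from compound 3 to compound 4 (0.00 log units; within the scatter) is therefore nothing beyond the scatter, in neither direction. In this assay compound 4 is estimated at 11000 nM (range 4500 nM to 25000 nM).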

Compound 4, half-maximal inhibitory concentration: > 25000 nM
Compound 4 gave a limit, no number; the forecaster's own chance of this, stated with the estimate: 15%; middle value at least 2.2-fold (0.35 log units) from the limit.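

In this assay, within the data shown here, this aromatic carbon gives the first single exchange that reaches beyond the scatter, with chloro in place of nitro: an at least 2.2-fold higher number from compound 3 to compound 4 (0.36 log units; beyond the scatter). The step from the 2-methoxyphenyl to the 3-chlorophenyl group, an at least 1.1-fold higher number from compound 2 to compound 4 (0.06 log units; that floor lies within the scatter), sets no order. Compound 4 reads only as a limit, so the size of both steps stays a floor: the limit of > 25000 nM in this assay, at which 2 of the 4 values shown sit.

With only nitro and chloro at this carbon, the compounds shown leave open whether nitro is specifically favoured there. As far as these compounds go, how an amine or a carboxylic acid at the same carbon would read also remains open.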